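A few compounds are considered here, and "the series" means these few. Any claim that something is new, unique, unknown or untested is made for them only; others in the source may bear on it.

Notes on the series in a functional assay on RKOp27 cells (Homo sapiens) for cytotoxicity, read by MTT assay, with a stated time of 3 days (a lower number here means a stronger inhibitor, a higher number a weaker inhibitor), so far. Compound 1 (`N#Cc1c(Cl)nc(SCc2nc3ccccc3[nH]2)nc1-c1ccccc1`) gives 4.38 nM and compound 2 (`N#Cc1c(Nc2nccs2)nc(SCc2nc3ccccc3[nH]2)nc1-c1ccccc1`) gives 3.2 nM here, so compound 2 stands level with compound 1 within the scatter. The change leading to compound 3 (`N#Cc1c(NNC(N)=S)nc(SCc2nc3ccccc3[nH]2)nc1-c1ccccc1`) is a group of 4 heavy atoms (1 carbon, 2 nitrogen, 1 sulfur; no ring) in place of a group of 5 heavy atoms (3 carbon, 1 nitrogen, 1 sulfur; one five-membered aromatic ring with 2 hetero atoms), on a nitrogen on an aromatic ring and it swaps the 1,3-thiazol-2-yl for a group with no ring. Among the measured compounds shown here, the only measured step that bears on it is a 1.4-fold lower number from compound 1 to compound 2 (0.14 log units; within the scatter) and this step, with (1,3-thiazol-2-yl)amino in place of chloro on an aromatic carbon, lies within the scatter. For the measured compounds named here, no measured step yet varies the group on that nitrogen, so the evidence is thin. In this assay no step beyond the scatter is expected, in either direction. The expected step is a 1.3-fold higher number from compound 2 to compound 3 (0.10 log units; within the scatter) as estimated from this single comparison. Compound 3 is estimated at 4 nM with an expected range from 1.3 nM to 13 nM in this series.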

Compound 3, half-maximal inhibitory concentration: 3.2 nM
Estimate against measurement, compound 3: 1.3-fold (0.10 log units) above; measured number inside the range.
By their numbers in this assay, from the lowest: compounds 2, 3 and 1 (each within the scatter of the next).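

In this assay the group on a nitrogen on an aromatic ring need not be a ring: replacing 1,3-thiazol-2-yl with the open group of compound 3 gives no change at the digits printed from compound 2 to compound 3 (within the scatter) and so extends the level readings to a second, quite different substituent. Set against the chloro compound, the same group gives a 1.4-fold lower number from compound 1 to compound 3 (0.14 log units; within the scatter) and so a second replacement of chloro on an aromatic carbon also stays level with compound 1. No measurement on these compounds accounts for this level result.

Going by these compounds, it remains open whether a plain amine or a carboxylic acid on that aromatic carbon, or a longer chain on that nitrogen, would stay level as well. With no step beyond the scatter so far, the series does not yet show which features of this group, if any, affect the number.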